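Fluorine to methyl on the cyclopropyl amide

The source may hold more compounds than are shown below. What is called first, only, known or untested is meant among the compounds shown, and "the series" means these compounds.

Three compounds share one bicyclic core and differ only in the ring on the carbonyl carbon. Compound 1 `O=C(C1CCC1)N1CC2CC(C1)N2` carries a cyclobutyl and in an assay on SH-EP1 cells for displacement of a labelled ligand from Neuronal acetylcholine receptor; alpha4/beta2 (Homo sapiens), read by scintillation counting (on this read-out lower numbers stand for stronger inhibition and higher numbers for weaker inhibition), compound 1 gives 16 nM. Compound 2 `O=C([C@H]1C[C@H]1F)N1CC2CC(C1)N2` gives 1.1 nM and compound 3 `O=C([C@H]1C[C@@H]1F)N1CC2CC(C1)N2` gives 5.4 nM. The change of cyclobutyl to 2-fluorocyclopropyl shows a 15-fold lower number from compound 1 to compound 2 (1.16 log units; beyond the scatter) and a 3.0-fold lower number from compound 1 to compound 3 (0.47 log units; beyond the scatter), while the two fluorocyclopropyl isomers themselves show a 4.9-fold higher number from compound 2 to compound 3 (0.69 log units; beyond the scatter). Compound 3 therefore stands second highest of the three numbers, nearer to compound 1 than to compound 2.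

Compound 4 `C[C@H]1C[C@H]1C(=O)N1CC2CC(C1)N2` is the next step from compound 3: 2-methylcyclopropyl in place of 2-fluorocyclopropyl on a carbonyl carbon. Within the data shown here, no measured pair compares a methyl with a fluorine on this ring, so the only guidance is indirect. The step from cyclobutyl to 2-fluorocyclopropyl was modest for compound 3, and the stereochemical pair of compounds 2 and 3 shows that the substituent on this small ring matters within a modest span. A swap of fluorine for methyl at the same place is expected to move the number by no more than a modest amount in this assay, direction uncertain. The estimate for compound 4 is 8 nM, between 2.5 nM and 25 nM, which means an expected step of a 1.5-fold higher number from compound 3 to compound 4 (0.17 log units; within the scatter).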

Compound 4, inhibition constant: 7 nM
Compound 4: the middle estimate sits 1.1-fold (0.06 log units) above what was measured; the range from low to high includes it.
By their numbers in this assay, from the lowest: compound 2; then compounds 3 and 4 (each within the scatter of the next); then compound 1.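

In this assay, 2-methylcyclopropyl in place of 2-fluorocyclopropyl on a carbonyl carbon gives a 1.3-fold higher number from compound 3 to compound 4 (0.11 log units; within the scatter), so the two groups cannot be told apart in this pairing, and fluorine is not needed to hold the number at this level. The same change read against the other fluorine isomer gives a 6.4-fold higher number from compound 2 to compound 4 (0.80 log units; beyond the scatter), which leaves that isomer clearly apart, while the step from the cyclobutyl amide, a 2.3-fold lower number from compound 1 to compound 4 (0.36 log units; beyond the scatter), shows that a substituted cyclopropyl without fluorine still keeps a gain over cyclobutyl. Nothing at hand gives a cause for these steps.

The compounds shown leave open whether the other configuration of the 2-methylcyclopropyl would bring a gap like a 4.9-fold higher number from compound 2 to compound 3 (0.69 log units; beyond the scatter), and so whether the methyl series follows the fluorine pair or not. They also leave open how a trifluoromethyl, a hydroxyl or an amine on the same cyclopropyl ring would read, and whether any group there could match the number of compound 2 at 1.1 nM.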